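Oxygen-ring series: 2-fluorophenyl replacing 4-ethylphenyl

The compounds below may be only part of what the source reports. "The series", "measured", "known", "first", "only" and "open" are said of these compounds alone.

Measured so far:
compound 1 `CCC1=C(O)c2c(oc(-c3ccc(C)cc3)cc2=O)C(CC)(CC)C1=O` — 0.08 uM
compound 2 `CCC1=C(O)c2c(oc(-c3ccc(CC)cc3)cc2=O)C(CC)(CC)C1=O` — 0.07 uM
compound 3 `CCOc1ccc(-c2cc(=O)c3c(o2)C(CC)(CC)C(=O)C(CC)=C3O)cc1` — 7.54 uM

In a functional assay on KBVIN cells (Homo sapiens) for antiproliferative activity, read by sulforhodamine B assay, with a stated time of 3 days (a higher number here means that more compound is needed for the effect, a lower number that less compound is needed), compound 2 gives the lowest of the three numbers. Its nearest neighbour is compound 1, and the step of a 1.1-fold lower number from compound 1 to compound 2 (0.06 log units; within the scatter) is small; its furthest neighbour is compound 3, and the step of a 110-fold higher number from compound 2 to compound 3 (2.03 log units; beyond the scatter) is large. The third measured step, a 94-fold higher number from compound 1 to compound 3 (1.97 log units; beyond the scatter), is of the same kind and size.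

Compound 4 `CCC1=C(O)c2c(oc(-c3ccccc3F)cc2=O)C(CC)(CC)C1=O` is not yet measured. The change from compound 2 is 2-fluorophenyl in place of 4-ethylphenyl on an aromatic carbon. For the measured compounds named here, none of the measured steps covers this change directly: the small step from compound 1 to compound 2 concerns only the length of the alkyl on the phenyl, and the two large steps concern an ethoxy on that phenyl. Going by the values given here, no step here shows what a fluorine, or a 2-substituted phenyl, does. The alkyl steps suggest that small variation on this ring need not move the number, while the ethoxy steps show that the ring is sensitive to some changes.

On that basis a moderate rise in the number is expected for compound 4, with wide uncertainty; the estimate is 0.3 uM, between 0.05 uM and 3 uM, meaning an expected step of a 4.3-fold higher number from compound 2 to compound 4 (0.63 log units; beyond the scatter).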

Compound 4, concentration for half-maximal effect: 3.93 uM
The estimate for compound 4 lay 13-fold (1.12 log units) below the measured number; the whole stated range lies below it.
By their numbers in this assay, from the lowest: compounds 2 and 1 (each within the scatter of the next); then compounds 4 and 3 (each within the scatter of the next).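

In this assay the sensitivity of this aryl position is not limited to the ethoxy change: 2-fluorophenyl in place of 4-ethylphenyl gives a 56-fold higher number from compound 2 to compound 4 (1.75 log units; beyond the scatter) and 2-fluorophenyl in place of 4-methylphenyl gives a 49-fold higher number from compound 1 to compound 4 (1.69 log units; beyond the scatter). Among the four compounds, the low numbers belong only to the two with a 4-alkylphenyl, while the two other aryl groups stay within the scatter of each other, with 2-fluorophenyl in place of 4-ethoxyphenyl giving a 1.9-fold lower number from compound 3 to compound 4 (0.28 log units; within the scatter). Nothing available explains why these aryl groups separate in this way.

Compound 4 loses the 4-alkyl group and gains the fluorine in a single change, so the shown compounds cannot tell whether the rise comes from the missing alkyl, from the fluorine, or from where the fluorine sits. From the compounds shown here alone, an unsubstituted phenyl, a fluorine elsewhere on the phenyl and a propyl chain in place of the ethyl of 4-ethylphenyl remain open, as does whether the low numbers hold beyond methyl and ethyl.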